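A few compounds are considered here, and "the series" means these few. Any claim that something is new, unique, unknown or untested is made for them only; others in the source may bear on it.

Compound 1, `COc1cccc(CN2CCC(CCOC(c3ccc(F)cc3)c3ccc(F)cc3)CC2)c1`, in an assay on isolated protein for binding affinity to sodium-dependent dopamine transporter (Rattus norvegicus); a higher number here means a weaker inhibitor, a lower number a stronger inhibitor: 13.3 nM
Compound 2, `Fc1ccc(C(OCCC2CCN(Cc3cccc4ccccc34)CC2)c2ccc(F)cc2)cc1`, in this assay: 16 nM
Compound 3, `Fc1ccc(C(OCCC2CCN(Cc3ccccc3)CC2)c2ccc(F)cc2)cc1`, in this assay: 9.9 nM

The three measured compounds share one core and differ only in the aromatic group carried on the benzylic carbon bound to the ring nitrogen. Compound 3 holds the lowest of the three numbers, but its neighbours sit close: the step of a 1.3-fold lower number from compound 1 to compound 3 (0.13 log units; within the scatter) and the step of a 1.6-fold lower number from compound 2 to compound 3 (0.21 log units; within the scatter) both fall within the scatter, as does a 1.2-fold higher number from compound 1 to compound 2 (0.08 log units; within the scatter), so none of the three can be set apart from the others on these data.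

Compound 4, `Cc1ccc(CN2CCC(CCOC(c3ccc(F)cc3)c3ccc(F)cc3)CC2)cc1`, is not yet measured. Relative to compound 3 it carries methyl in place of hydrogen on an aromatic carbon.

Within the data shown here, the steps that bear on this change are those in which the same benzylic aromatic group was altered: a 1.3-fold lower number from compound 1 to compound 3 (0.13 log units; within the scatter), a substituent removed from the phenyl ring, and a 1.6-fold lower number from compound 2 to compound 3 (0.21 log units; within the scatter), the ring system itself exchanged. Neither moved the number beyond the scatter. A methyl added to that phenyl ring is therefore expected to give a step of a 1.1-fold higher number from compound 3 to compound 4 (0.05 log units; within the scatter) that stays within the scatter. For compound 4 the expected value in this assay is 11 nM, with a range from 5 nM to 25 nM.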

Compound 4, inhibition constant: 5.7 nM
Compound 4: the middle estimate sits 1.9-fold (0.29 log units) above what was measured, and the stated range covers the measured number.
By their numbers in this assay, from the lowest: compounds 4, 3, 1 and 2 (each within the scatter of the next, the first and the last beyond it).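

Placing a methyl on this aromatic carbon, para to a large group, gives a 1.7-fold lower number from compound 3 to compound 4 (0.24 log units; within the scatter) in this assay and so adds one carbon here without a step that leaves the scatter. Among these compounds, compound 4 also supplies the first steps in this set that pass beyond the scatter, namely a 2.8-fold lower number from compound 2 to compound 4 (0.45 log units; beyond the scatter) and a 2.3-fold lower number from compound 1 to compound 4 (0.37 log units; beyond the scatter) where every step among the three earlier compounds stayed within it, so the 4-methylphenyl group can be set apart from the naphthalen-1-yl and 3-methoxyphenyl groups even though it cannot be set apart from the unsubstituted phenyl group of compound 3. Nothing available accounts for the size of these steps.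

The step from compound 1 to compound 4 changes both the substituent and its place on the ring, so these compounds do not separate the effect of the group from that of its position, and a 3-methylphenyl or 4-methoxyphenyl group would be needed to do so. From the compounds shown here alone, it also remains open whether a longer chain such as ethyl, a halogen such as chlorine, or a hydroxyl group at this same place would stay within the scatter of compound 3 or move beyond it.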